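A few compounds are considered here, and "the series" means these few. Any claim that something is new, unique, unknown or untested is made for them only; others in the source may bear on it.

In an ADME assay on Vero cells (Chlorocebus sabaeus) for cytotoxicity, with a stated time of 72 h (a lower number here means a stronger inhibitor, a higher number a weaker inhibitor), compound 1 (`CCOC(=O)c1cc(/C=C/c2ccncc2)on1`) gives > 128000 nM as a limit of the assay and not a number. Compound 2 (`CCOC(=O)c1cc(/C=C\c2cc(F)cc(F)c2)on1`) gives > 128000 nM as a limit too. Compound 3 (`CCOC(=O)c1cc(/C=C/c2cccc([N+](=O)[O-])c2)on1`) gives > 128000 nM as a limit as well. Compound 1 therefore has no exact number and shares the limit of > 128000 nM in this assay, at which 3 of the 3 values shown sit, with the other two.

Compound 4 (`CCOC(=O)c1cc(/C=C/c2ccsc2)on1`) has thiophen-3-yl in place of pyridin-4-yl on a double-bonded chain carbon bound to a double-bonded chain carbon. Going by the values given here, no pair of measured compounds gives a step that could size this swap directly. The three measured compounds do differ in the group on the chain, yet all sit at the same limit. No step beyond the scatter is therefore expected in either direction. The estimated change is a number no higher from compound 1 to compound 4 (the limit leaves the size open) in the same measure. This expectation rests on compound 1 with its limit of > 128000 nM as the starting point. For compound 4 the expected value is 128000 nM with an estimated range from 70000 nM to 128000 nM in this test.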

Compound 4, half-maximal inhibitory concentration: > 128000 nM
Compound 4 gave a limit, no number (the forecaster's own chance of this, stated with the estimate: 85%); the middle value sits exactly at the limit.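

Going by these compounds alone, compound 1 and compound 4 both give a limit of the assay and not a number, so no step between them can be read. The compounds shown leave open whether swapping the group on the chain changes the result in this assay at all, as they share one limit: the limit of > 128000 nM in this assay, at which 4 of the 4 values shown sit.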